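Series notes: aryl swap on the ring amine nitrogen

This account rests on a few compounds, and the source may have more. Where it says the series, first, only, none or still open, it means among the compounds named here.

Measured so far in a functional assay on CHO cells with adenosine receptor A1 (Homo sapiens) as the target, read by cAMP accumulation and immunoassay, with a stated time of 6 min, tested at 0.01 uM; a higher number here means a weaker effect of the compound at the concentration tested, a lower number a stronger effect:
compound 1, `Nc1scc(CN2CCN(c3ccc([N+](=O)[O-])cc3)CC2)c1C(=O)c1ccc(Cl)cc1`: -12%
compound 2, `Nc1scc(CN2CCC(c3ccc(Cl)cc3)CC2)c1C(=O)c1ccc(Cl)cc1`: 0%
compound 3, `Nc1scc(CN2CCN(c3ccc(C(F)(F)F)cc3)CC2)c1C(=O)c1cccc(C(F)(F)F)c1`: -12%

All three numbers sit close to zero. Compound 1 is level with compound 3 in this assay, and together these two are the lowest of the three; compound 2 stands higher than compound 1, a gap beyond the usual scatter, while the gap from compound 1 to compound 3 lies within it. Among the measured compounds shown here, no pair among the measured compounds differs in a single place, so no measured step is available for this series.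

Compound 4, `Nc1scc(CN2CCN(c3ccc(F)cc3F)CC2)c1C(=O)c1ccc(Cl)cc1`, is not yet measured. It differs from compound 1 in one place: 2,4-difluorophenyl in place of 4-nitrophenyl on an amine nitrogen in a ring. The rest of the structure, the shared core of compound 1, is kept.

Nothing measured here ties this kind of change to a shift in this assay. The neighbouring values of compound 1 and compound 3 both lie near zero, and compound 2 is not far off, so the expectation for compound 4 is a step of no size beyond the scatter, a number 4 percentage points higher from compound 1 to compound 4 (within the scatter). The estimate for compound 4 in this assay is -8%, with a range from -25% to 10%.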

Compound 4, a percentage reported as activity, at one concentration (the size of the read-out at that concentration, not a potency): 0%
Estimate against measurement, compound 4: 8 percentage points below; the measured number falls inside the stated range.
By their numbers in this assay, from the lowest: compounds 1 and 3 (each within the scatter of the next); then compounds 2 and 4 (each within the scatter of the next).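

In this assay, the series now has a step at a single place: a number 12 percentage points higher from compound 1 to compound 4 (beyond the scatter). The number at this position, on an amine nitrogen in a ring, therefore moves with the aryl group it carries, though the step is modest and rests on one pair of compounds, in which 4-nitrophenyl, which has hydrogen-bond acceptors, leaves and 2,4-difluorophenyl, which has none, enters. No supporting data bear on what lies behind this shift, so the observation stands without an explanation.

This one pair removes the nitro group and adds the two fluorines in a single change, leaving open whether the shift follows the departure of one, the arrival of the other, or both, and a plain phenyl on the same nitrogen would be the natural group to separate them. Also open, on these data alone, is how far the position tolerates other groups, such as a 4-methoxyphenyl, a 4-cyanophenyl or a non-aromatic acetyl on that nitrogen, and whether any of them moves the number further from that of compound 1.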